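Sulfonamide series: switch to 4-ethylphenyl on the sulfonyl

A few compounds are considered here, and "the series" means these few. Any claim that something is new, unique, unknown or untested is made for them only; others in the source may bear on it.

Measured so far:
compound 1, `O=S(=O)(Nc1ccc(-c2nc3ccccc3o2)cc1)c1cccs1`, 63000 nM
compound 2, `N#Cc1ccc(S(=O)(=O)Nc2ccc(-c3nc4cc(NS(=O)(=O)c5ccc(C#N)cc5)ccc4o3)cc2)cc1`, 49000 nM
compound 3, `Cc1cccc(S(=O)(=O)Nc2ccc3oc(-c4ccccc4)nc3c2)c1`, gives only a limit

In an assay on cells for inhibition of HSP60/HSP10 (Homo sapiens), with a stated time of 60 min (on this read-out higher numbers stand for weaker inhibition and lower numbers for stronger inhibition), compound 1 gives 63000 nM. Among the two numbers in hand compound 1 carries the higher one, but compound 2 sits so close that the two are within the usual scatter and no order between them can be claimed. For compound 3 the read-out is not a number but a limit of the assay, > 100000 nM, (the limit of > 100000 nM in this assay, at which 1 of the 3 values shown sits). All three measured compounds therefore sit at the weak end of what this assay can resolve.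

Compound 4, `CCc1ccc(S(=O)(=O)Nc2ccc(-c3nc4ccccc4o3)cc2)cc1`, is not yet measured. It differs from compound 1 in one place: 4-ethylphenyl in place of thiophen-2-yl on a sulfonyl sulfur. Among the compounds with values here, no measured pair shows this kind of exchange, so the direction has to be taken from the general level of the series, which is weak throughout. The expected step from compound 1 to compound 4 is a 1.1-fold higher number from compound 1 to compound 4 (0.05 log units; within the scatter), that is, no change beyond the scatter, with a real chance that compound 4 only returns a limit. The estimate for compound 4 in this assay is 70000 nM, expected to lie between 25000 nM and 200000 nM.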

Compound 4, half-maximal inhibitory concentration: > 100000 nM
Compound 4 ended at the assay's limit (the forecaster's own chance of this, stated with the estimate: 35%); middle value at least 1.4-fold (0.15 log units) away from the limit.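

In this assay, placing 4-ethylphenyl in place of thiophen-2-yl on a sulfonyl sulfur gives an at least 1.5-fold higher number from compound 1 to compound 4 (0.20 log units; that floor lies within the scatter). The read-out for compound 4 is a limit of the assay and not a number, so this step has a floor but no measured size, and a real loss on leaving thiophen-2-yl can be neither claimed nor excluded. This is the first exchange readable at this position, and it shows that the carbon-only six-membered aromatic ring of 4-ethylphenyl brings no gain over the five-membered ring with its hetero atom, while the series moves further onto the ceiling of the read-out: the limit of > 100000 nM in this assay, at which 2 of the 4 values shown sit.

As far as these compounds go, how far compound 4 actually lies from compound 1 stays open, as does whether any group on this sulfonyl sulfur can bring the read-out clearly into the measurable range. A carboxylic acid or an amine in place of the ethyl of 4-ethylphenyl would test whether this position can respond at all, since the two groups compared here leave that question unanswered.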